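Thiophene in Place of Methoxyphenyl on a Shared Core

The source may report more compounds than this note shows. Statements on the series, on what has been measured and on what is new or still open speak of the compounds shown alone.

Compound 1 `Cc1cc(-c2cccc(F)c2)c2ncc(CSCCc3ccccc3)n2c1` and compound 2 `COc1cccc(-c2cc(C)c3ncc(CSCCc4ccccc4)n3c2)c1` share a core and differ only in the group attached to it. In an ADME assay on HEL cells (Homo sapiens) for cytotoxicity, with a stated time of 3 days (a lower number here means that less compound is tolerated, a higher number that more compound is tolerated), compound 1 gives 20 ug/mL, and compound 2 gives 20 ug/mL. Compound 2 thus stands level with compound 1, its nearest neighbour, at the digits shown, with no change beyond the scatter. Compound 3 `Cc1cc(-c2cccs2)cn2c(CSCCc3ccccc3)cnc12` has not yet been measured in this assay. Relative to compound 2 the change is thiophen-2-yl in place of 3-methoxyphenyl on an aromatic carbon. Going by the values given here, no step between two measured compounds is available to give a scale for this change; the values of compounds 1 and 2 show only that one exchange of the attached group left the read-out unchanged within the scatter. Compound 3 is expected to give 20 ug/mL in this assay, with a range from 10 ug/mL to 40 ug/mL. This estimate implies a step of no change at the digits printed from compound 2 to compound 3 (within the scatter), expected to remain within the scatter.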

Compound 3, minimum cytotoxic concentration: 20 ug/mL
Compound 3: the middle estimate sits on the measured number at the digits printed; low and high end bracket the measured number.
By their numbers in this assay, from the lowest: compounds 1, 2 and 3 (each within the scatter of the next).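

Thiophen-2-yl in place of 3-methoxyphenyl on this aromatic carbon gives no change at the digits printed from compound 2 to compound 3 (within the scatter) in this assay and so supplies the first step at this position that can be read between two measured compounds. The level reading of compounds 1 and 2 had involved only six-membered aromatic rings of carbon, whereas this step shows the read-out also staying within the scatter with a five-membered aromatic ring with 1 hetero atom, which has fewer heavy atoms than the group it replaces. No measurement shown explains this outcome.

On these data alone, what a group of another kind on this aromatic carbon, such as an amine, a carboxylic acid or a longer chain, would do to the read-out remains open. Also open, as far as these compounds go, is how far the read-out depends on the rest of the molecule, as all three compounds keep the same shared core and the same chain.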